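N-Methylation of a Bridged Amine Across Two Pyridine Cores

The compounds below may be only part of what the source reports. "The series", "measured", "known", "first", "only" and "open" are said of these compounds alone.

Compound 1 `C1=C(c2cccnc2)C[C@@H]2CNC[C@H]1C2`: 1.4 nM
Compound 2 `CN1C[C@@H]2C=C(c3cccnc3)C[C@@H](C2)C1`: 855 nM
Compound 3 `CC(C)Oc1cncc(C2=CC3CNCC(C2)C3)c1`: 1090 nM

Three compounds were measured in a functional assay on synaptosomes from brain (strain Sprague-Dawley) for agonist activity at Nicotinic acetylcholine receptor alpha6/alpha3/beta2/beta3 (Rattus norvegicus); on this read-out higher numbers stand for an effect only at larger amounts of compound and lower numbers for an effect already at smaller amounts. Compound 1 gives 1.4 nM in this assay, the lowest of the three numbers. Compound 2 carries the change methyl in place of hydrogen on an amine nitrogen in a ring relative to compound 1, and this change made the step of a 610-fold higher number from compound 1 to compound 2 (2.79 log units; beyond the scatter). Compound 3 gives 1090 nM in this assay; its number and that of compound 2 lie within the scatter of each other, so no order between them is claimed. How the core of compound 3 differs from the core of compound 1 is not broken down here.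

Compound 4 `CC(C)Oc1cncc(C2=CC3CC(C2)CN(C)C3)c1` has not yet been measured. It differs from compound 3 by methyl in place of hydrogen on an amine nitrogen in a ring, the same change that led from compound 1 to compound 2, made at the same place. Only one measured instance of this change exists among these compounds, and it sits on a different core, so the expectation for compound 4 rests on the single step of a 610-fold higher number from compound 1 to compound 2 (2.79 log units; beyond the scatter) applied to the value of compound 3. On that basis compound 4 is expected to give about 150000 nM in this assay, with a range from 15000 nM to 1000000 nM. The expected number means a step of a 140-fold higher number from compound 3 to compound 4 (2.14 log units; beyond the scatter).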

Compound 4, half-maximal effective concentration: 879 nM
The estimate for compound 4 lay 170-fold (2.23 log units) above the measured number, outside the stated range (below it).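

In this assay, methyl in place of hydrogen on the amine nitrogen gave a 1.2-fold lower number from compound 3 to compound 4 (0.09 log units; within the scatter), so on this core the change leaves the number within the scatter. Set beside the earlier step, the same change at the same place does not carry over in size from one core to the other: the same change on two cores in this assay, a 610-fold higher number (2.79 log units; beyond the scatter) from compound 1 to compound 2 and a 1.2-fold lower number (0.09 log units; within the scatter) from compound 3 to compound 4, 760-fold (2.88 log units) apart, beyond the scatter of two such steps. This shows that the step seen on the core of compound 1 cannot be used as a guide for the core of compound 3, but it does not show what in the two cores sets the steps apart, and two pairs of compounds give no rule for any further core.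

The compounds shown leave open whether ethyl or a longer chain on the amine nitrogen would follow methyl on either core. They also leave open whether a methoxy group in place of the isopropyl ether of compound 3 and compound 4 would bring the effect of the methyl group closer to the step seen on the core of compound 1.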